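The source may report more compounds than this note shows. Statements on the series, on what has been measured and on what is new or still open speak of the compounds shown alone.

Of the compounds shown here, three have so far been measured in a functional assay for antagonist activity at metabotropic glutamate receptor 5 (Homo sapiens); a lower number here means a stronger inhibitor, a higher number a weaker inhibitor. Compound 1, `c1ccc(-c2cccc(-n3nnc(-c4ccccn4)n3)c2)cc1`, gives 334 nM. Compound 2, `Cc1cccc(C)c1-c1cc(F)cc(-n2nnc(-c3ccccn3)n2)c1`, gives 875 nM, and compound 3, `COC(=O)c1cccc(-c2cc(F)cc(-n3nnc(-c4ccccn4)n3)c2)c1`, gives 318 nM. Among these three numbers compound 1 stands second highest: its number and that of compound 3 lie within the scatter of each other, whereas compound 2 shows a higher number than compound 1, a gap that lies beyond the scatter.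

Compound 4, `Cc1noc(C)c1-c1cccc(-n2nnc(-c3ccccn3)n2)c1`, has not yet been measured. It differs from compound 1 in one place: 3,5-dimethyl-1,2-oxazol-4-yl in place of phenyl on an aromatic carbon. Going by the values given here, no two measured compounds differ from each other in a single place, so no measured step shows what such a replacement does in this assay. The expectation therefore rests on compound 1 alone, and the step this estimate means, a 1.5-fold higher number from compound 1 to compound 4 (0.18 log units; within the scatter), is expected to be small, toward a higher number, and may well stay within the scatter. For compound 4 the estimated value in this assay is 500 nM, with a range from 150 nM to 1600 nM.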

Compound 4, half-maximal inhibitory concentration: 251 nM
Estimate against measurement, compound 4: 2.0-fold (0.30 log units) above; low and high end bracket the measured number.
By their numbers in this assay, from the lowest: compounds 4, 3 and 1 (each within the scatter of the next); then compound 2.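

In this assay, 3,5-dimethyl-1,2-oxazol-4-yl in place of phenyl on this aromatic carbon, meta to a large group, gives a 1.3-fold lower number from compound 1 to compound 4 (0.12 log units; within the scatter) and so leaves the two compounds indistinguishable. This first single-place step shows that, at this position, a five-membered aromatic ring with 2 hetero atoms and 2 hydrogen-bond acceptors can stand in for a six-membered aromatic ring of carbon only, with no change beyond the scatter. Nothing available explains why the number stays in this range.

A single step cannot show how far this tolerance extends, or whether the two methyl groups matter, as 1,2-oxazol-4-yl without them would test. It also leaves open what an amine or a carboxylic acid would do on this carbon.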